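Removing a Bromine from the Side-Chain Phenyl

The source may hold more compounds than are shown below. What is called first, only, known or untested is meant among the compounds shown, and "the series" means these compounds.

Two compounds share the same core and differ only in the chain attached to it. Compound 1 `OCC(O)Cn1nc2c(Br)c(Br)c(Br)c(Br)c2n1` carries a short chain bearing two hydroxyl groups; in a functional assay on CCRF-CEM cells (Homo sapiens) for antiproliferative activity, read by MTT assay, with a stated time of 24 h, tested at 12.5 uM (a higher number here means a weaker effect of the compound at the concentration tested, a lower number a stronger effect), compound 1 gives 78%. Compound 2 `OC(CCn1nc2c(Br)c(Br)c(Br)c(Br)c2n1)c1ccc(Br)cc1` carries a 4-bromophenyl group on its chain, and in this assay compound 2 gives 101%, the highest of the two numbers and a value beyond the scatter above compound 1, so compound 2 shows the weaker effect at the tested concentration. Compound 3 `OC(CCn1nc2c(Br)c(Br)c(Br)c(Br)c2n1)c1ccccc1` differs from compound 2 by hydrogen in place of bromo on an aromatic carbon. Among the compounds with values here, no measured pair shows this change, so its effect on the read-out is unknown. Because compound 2 gives 101%, a value close to no effect, the step expected from compound 2 to compound 3 is small, a number 6 percentage points lower from compound 2 to compound 3 (within the scatter), and within the scatter. Compound 3 is estimated at 95%, in a range from 80% to 110%.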

Compound 3, a percentage reported as activity, at one concentration (the size of the read-out at that concentration, not a potency): 122%
Compound 3: middle estimate off by 27 percentage points, on the low side; the whole stated range lies below it.
By their numbers in this assay, from the lowest: compound 1; then compound 2; then compound 3.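

Within the data shown here, the change from 4-bromophenyl to phenyl gives a number 21 percentage points higher from compound 2 to compound 3 (beyond the scatter) in this assay, so this is the first measured pair to isolate a single change, and the spot on the aromatic ring, para to a large group, does affect the read-out. Since a higher number means a weaker effect, the bromo goes with the stronger effect of the two, even though both compounds sit at the weak end of the scale and compound 3, at 122%, reads further from a real effect. Nothing measured here accounts for this difference.

The compounds shown leave open whether another group at this place, such as a chlorine, a methoxy group or an amine, would lower the number further. They also leave open whether the same change would matter on a chain of a different length.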